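Methoxy to dimethylamino on the core of compound 3

A few compounds are considered here, and "the series" means these few. Any claim that something is new, unique, unknown or untested is made for them only; others in the source may bear on it.

Three compounds of the series have numbers in a functional assay on HL-60 cells (Homo sapiens) for antiproliferative activity, read by XTT assay, with a stated time of 72 h; a lower number here means a stronger inhibitor, a higher number a weaker inhibitor. Compound 3 `COc1ncnc2c1c(-c1cccs1)cn2[C@@H]1O[C@H](CO)[C@@H](O)[C@H]1O` gives 80 nM, the lowest of the three; compound 1 `COc1ncnc2c1c(-c1ccsc1)cn2[C@@H]1O[C@H](CO)[C@@H](O)[C@H]1O` gives 130 nM, and the change from compound 1 to compound 3, thiophen-2-yl in place of thiophen-3-yl on an aromatic carbon, amounts to a 1.6-fold lower number from compound 1 to compound 3 (0.21 log units; within the scatter). Within the data shown here, compound 2 `CN(C)c1ncnc2c1c(-c1ccoc1)cn2[C@@H]1O[C@H](CO)[C@@H](O)[C@H]1O` gives 1160 nM, the only number far from compound 3.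

Compound 4 `CN(C)c1ncnc2c1c(-c1cccs1)cn2[C@@H]1O[C@H](CO)[C@@H](O)[C@H]1O` is the next step from compound 3: dimethylamino in place of methoxy on an aromatic carbon.

Among the measured compounds shown here, no measured step covers this change alone. For the measured compounds named here, compound 2 is the one compound carrying dimethylamino, but it differs from compound 1 in a second place as well, so its gap to compound 1 cannot be split between the two changes; what the two values show is that the dimethylamino compound sits well weaker. On that indirect ground the step to compound 4 is expected to raise the number in this assay, with a size that is uncertain and could fall anywhere from inside the scatter to most of the gap seen between compound 1 and compound 2.

The expected step is a 5.0-fold higher number from compound 3 to compound 4 (0.70 log units; beyond the scatter). Compound 4 is therefore estimated at 400 nM, with a range of 120 nM to 1500 nM.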

Compound 4, half-maximal inhibitory concentration: 11800 nM
Estimate against measurement, compound 4: 30-fold (1.47 log units) below, and the stated range ends below it.
By their numbers in this assay, from the lowest: compounds 3 and 1 (each within the scatter of the next); then compound 2; then compound 4.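

In this assay, the change from methoxy to dimethylamino on the aromatic carbon next to the ring nitrogen can now be read on its own, with thiophen-2-yl held fixed: it gives a 150-fold higher number from compound 3 to compound 4 (2.17 log units; beyond the scatter), a far larger step than the gap between compound 1 and compound 2 had suggested. Among these compounds, with dimethylamino held fixed, the other substituent also counts, with a 10-fold higher number from compound 2 to compound 4 (1.01 log units; beyond the scatter) for thiophen-2-yl in place of furan-3-yl, whereas the one aryl step on the methoxy core, a 1.6-fold lower number from compound 1 to compound 3 (0.21 log units; within the scatter), stays within the scatter, so the aryl group separates the dimethylamino pair but not that methoxy pair. Nothing available accounts for the size of either large step.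

The compounds shown leave open whether the methoxy to dimethylamino step keeps its size with thiophen-3-yl or furan-3-yl in place of thiophen-2-yl, and whether furan-3-yl on the methoxy core differs from the thiophenes at all. A primary amine, a methylamino group or an ethoxy chain on the same carbon would show whether the large step goes with the nitrogen itself or with its two methyl groups.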